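The compounds below may be only part of what the source reports. "The series", "measured", "known", "first", "only" and "open" are said of these compounds alone.

Working notes on the series. Among the compounds with values here, in a functional assay on HepG2 cells (Homo sapiens) for antiproliferative activity, read by MTT assay, with a stated time of 48 h (on this read-out higher numbers stand for weaker inhibition and lower numbers for stronger inhibition), compound 1 (`COc1ccc(/C=C/c2cc(OC)cc(OC)c2/C=C/C(=O)c2ccc(Cl)cc2)cc1`) gives 13.6 ug/mL and compound 2 (`COc1ccc(/C=C/c2cc(OC)cc(OC)c2/C=C/C(=O)c2ccccc2)cc1`) gives 6.8 ug/mL, so compound 2 stands within the scatter of the only other measured number. Next in line is compound 3 (`COc1ccc(/C=C/c2cc(OC)cc(OC)c2/C=C/C(=O)c2ccc(-c3ccccc3)cc2)cc1`), with the change phenyl in place of hydrogen on an aromatic carbon, para to a large group, or phenyl to 4-phenylphenyl. Within the data shown here, one measured step bears on this: a 2.0-fold lower number from compound 1 to compound 2 (0.30 log units; within the scatter), hydrogen in place of chloro on an aromatic carbon. Among the measured compounds shown here, it is a single step, and no measured compound carries a ring at that place, so it guides only loosely. In this assay no step beyond the scatter is therefore expected, and the range is kept wide. The expected step is a 1.3-fold higher number from compound 2 to compound 3 (0.12 log units; within the scatter). For compound 3 the estimated value is 9 ug/mL, with an expected range of 3.5 ug/mL to 25 ug/mL.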

Compound 3, half-maximal inhibitory concentration: 10.5 ug/mL
For compound 3 the middle estimate is 1.2-fold (0.07 log units) below the measured one; measured number inside the range.
By their numbers in this assay, from the lowest: compounds 2, 3 and 1 (each within the scatter of the next).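

In this assay, within the data shown here, the earlier compounds covered only hydrogen and chloro at this place, whereas compound 3 carries a phenyl ring there, on an aromatic carbon para to a large group. Adding these 6 heavy atoms gives a 1.5-fold higher number from compound 2 to compound 3 (0.19 log units; within the scatter), and exchanging chloro for phenyl gives a 1.3-fold lower number from compound 1 to compound 3 (0.11 log units; within the scatter), so a whole aromatic ring at this place shifts the number no further than the scatter, and hydrogen, chloro and phenyl cannot be ranked here. No measurement at hand accounts for these steps.

On these data alone, whether any group at this place can give a step beyond the scatter remains open. An amine, a carboxylic acid or a longer chain there could test this, since all three groups seen so far leave the numbers within the scatter of one another.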